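This account rests on a few compounds, and the source may have more. Where it says the series, first, only, none or still open, it means among the compounds named here.

Compound 1 `CCCC[C@H](N)C(=O)N[C@@H]1C[C@H](C(=O)NO)N(S(=O)(=O)c2ccc(OC)cc2)C1` gives 98 nM in an assay on isolated protein for inhibition of matrix metalloproteinase-9 (Homo sapiens), read by fluorescence (on this read-out higher numbers stand for weaker inhibition and lower numbers for stronger inhibition), the highest number among the three compounds measured. Compound 2 `COc1ccc(S(=O)(=O)N2C[C@H](NC(=O)[C@H](CCCCN)NC(=O)OC(C)(C)C)C[C@@H]2C(=O)NO)cc1` gives 27 nM in this assay, and compound 3 `COc1ccc([S+]([O-])N2C[C@H](NC(=O)C(C)(C)C)C[C@@H]2C(=O)NO)cc1` gives 13 nM; both of these are beyond the scatter away from compound 1. Compound 4 `COc1ccc(S(=O)(=O)N2CCC[C@@H]2C(=O)NO)cc1` has not yet been measured. It differs from compound 1 by a hydrogen atom in place of a group of 9 heavy atoms (6 carbon, 2 nitrogen, 1 oxygen; no ring), on a saturated ring carbon, so the shared core keeps only its arylsulfonyl group and its hydroxycarbamoyl group. Among the compounds with values here, no measured pair in this set shows the effect of this change, and the three measured compounds all carry an amide on that ring carbon. The step from compound 1 to compound 4 is expected to be a 2.0-fold higher number from compound 1 to compound 4 (0.31 log units; beyond the scatter), towards weaker inhibition. Compound 4 is estimated at 200 nM, within 40 nM to 1000 nM.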

Compound 4, half-maximal inhibitory concentration: 22 nM
Estimate against measurement, compound 4: 9.1-fold (0.96 log units) above, and the stated range ends above it.
By their numbers in this assay, from the lowest: compounds 3, 4 and 2 (each within the scatter of the next, the first and the last beyond it); then compound 1.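

With a hydrogen atom in place of the group of 9 heavy atoms on the saturated ring carbon, this assay shows a 4.5-fold lower number from compound 1 to compound 4 (0.65 log units; beyond the scatter), towards stronger inhibition. Within the data shown here, the amide that all the earlier compounds carry on that ring carbon is therefore not required for inhibition, and the amide of compound 1 gives a weaker result than no substituent at all. No measurement shown explains this step.

The compounds shown leave open how a lone amine or a hydroxyl on that ring carbon would compare with the hydrogen atom of compound 4.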